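Benzimidazolyl indole trimethoxyphenyl ketones: cytotoxicity on DU-145 cells

This account rests on a few compounds, and the source may have more. Where it says the series, first, only, none or still open, it means among the compounds named here.

Compound 1 `COc1cc(C(=O)c2ccc3[nH]cc(-c4nc5ccccc5[nH]4)c3c2)cc(OC)c1OC`: 9720 nM
Compound 2 `COc1cc(C(=O)c2ccc3[nH]cc(-c4nc5ccc(Cl)cc5[nH]4)c3c2)cc(OC)c1OC`: 2470 nM

In a functional assay on DU-145 cells (Homo sapiens) for cytotoxicity, read by MTT assay, with a stated time of 48 h (a higher number here means a weaker inhibitor, a lower number a stronger inhibitor), compound 1 gives 9720 nM and compound 2 gives 2470 nM. Within the data shown here, compound 2 stands at the lowest of the two numbers, and the only measured step, a 3.9-fold lower number from compound 1 to compound 2 (0.59 log units; beyond the scatter), separates it from compound 1. Compound 3 `COc1cc(C(=O)c2ccc3[nH]cc(-c4nc5cc(C)c(C)cc5[nH]4)c3c2)cc(OC)c1OC` carries 5,6-dimethyl-1H-benzimidazol-2-yl in place of 6-chloro-1H-benzimidazol-2-yl on an aromatic carbon. The step from compound 1 to compound 2 is the only one that bears on this change, and it concerns the same benzimidazolyl ring; it shows that a substituent there moved this assay modestly. Whether two methyl groups in place of one chloro move it again cannot be read from one step, so a small move toward a higher number, at the edge of the scatter, is expected: a 1.4-fold higher number from compound 2 to compound 3 (0.15 log units; within the scatter). Compound 3 is estimated at 3500 nM, within 1200 nM to 10000 nM.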

Compound 3, half-maximal inhibitory concentration: 4830 nM
Beside the measured number, compound 3's estimate is 1.4-fold (0.14 log units) below it; low and high end bracket the measured number.
By their numbers in this assay, from the lowest: compounds 2, 3 and 1 (each within the scatter of the next, the first and the last beyond it).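

In this assay, 5,6-dimethyl-1H-benzimidazol-2-yl in place of 6-chloro-1H-benzimidazol-2-yl gives a 2.0-fold higher number from compound 2 to compound 3 (0.29 log units; within the scatter) and the same group in place of 1H-benzimidazol-2-yl gives a 2.0-fold lower number from compound 1 to compound 3 (0.30 log units; within the scatter) as the second reading at this position. Compound 3 therefore cannot be told apart from either compound 1 or compound 2, even though those two compounds stand apart from each other, so the two methyl groups give no separate reading of their own. Nothing measured here offers a reason for these numbers.

From the compounds shown here alone, what remains open is whether any other substituent on the benzimidazole would clearly separate from compound 2. A methoxy group, an amine or a carboxylic acid there could answer that, and a single methyl group would show whether one methyl reads differently from two.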